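Fluoropyridyl for phenyl on a piperidinylbutyl urea

A few compounds are considered here, and "the series" means these few. Any claim that something is new, unique, unknown or untested is made for them only; others in the source may bear on it.

Among the compounds with values here, compound 2 `O=C(NCCCCN1CCCCC1)Nc1ccc(-c2ccccc2)cc1` gives 7900 nM in a functional assay on HEK293 cells for agonist activity at 5-hydroxytryptamine receptor 3A (Homo sapiens), read by FLIPR (a higher number here means a weaker inhibitor, a lower number a stronger inhibitor), the larger of the two numbers so far, though within the scatter of compound 1 `O=C(NCCCCN1CCCCC1)Nc1ccc(-c2ccc(F)cc2)cc1`, which gives 5800 nM. Within the data shown here, the one measured step, a 1.4-fold higher number from compound 1 to compound 2 (0.13 log units; within the scatter), covers the fluoro alone. Compound 3 `O=C(NCCCCN1CCCCC1)Nc1ccc(-c2ccc(F)nc2)cc1` differs from compound 2 by 6-fluoropyridin-3-yl in place of phenyl on an aromatic carbon. Among the measured compounds shown here, the fluoro returns, which the earlier step suggests moves little; no measured step covers the ring nitrogen. The expected step is therefore a 1.2-fold lower number from compound 2 to compound 3 (0.08 log units; within the scatter), within the scatter. Compound 3 is estimated at 6500 nM, with a range from 2500 nM to 17000 nM.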

Compound 3, half-maximal inhibitory concentration in the 5-hydroxytryptamine receptor 3A assay: > 30000 nM
Compound 3: a limit, no number; the forecaster's own chance of this, stated with the estimate: 5%; at least 4.6-fold (0.66 log units) between middle value and limit.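

In the 5-hydroxytryptamine receptor 3A assay compound 3 gives > 30000 nM, which stands as a limit and not a number: the limit of > 30000 nM in the 5-hydroxytryptamine receptor 3A assay, at which 1 of the 3 values shown sits. Also in the 5-hydroxytryptamine receptor 3A assay, this aromatic carbon, para to a large group, proves sensitive to the ring change: the record shows an at least 3.7-fold higher number from compound 2 to compound 3 (0.57 log units; beyond the scatter) against phenyl and an at least 5.1-fold higher number from compound 1 to compound 3 (0.71 log units; beyond the scatter) against 4-fluorophenyl, where the fluoro stays and the ring nitrogen is what enters. In a physicochemical assay for solubility, at pH 7.4 (a higher number here means a more soluble compound, a lower number a less soluble compound), compound 2 gives 108000 nM and compound 3 gives 158000 nM; the same change gives a 1.5-fold higher number from compound 2 to compound 3 (0.17 log units; within the scatter) and so separates nothing there.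

From the compounds shown here alone, whether pyridin-3-yl without the fluoro, or a methoxy group in its place, would behave the same stays open, as does the true value of compound 3.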